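Chain-extended iodoacetamide nucleotides against hexokinase-3

The compounds below may be only part of what the source reports. "The series", "measured", "known", "first", "only" and "open" are said of these compounds alone.

Three chain-linked iodoacetamide nucleotides were examined for inhibition of hexokinase-3. In an assay on isolated protein for inhibition of hexokinase-3 (Rattus norvegicus), with a stated time of 6 h, tested at 10 mM (a lower number here means less inhibition, a higher number more inhibition at the concentration tested (going by the name of the read-out)), compound 3 `O=C(CI)NCCNc1ncnc2c1ncn2[C@@H]1O[C@H](COP(=O)(O)OP(=O)(O)OP(=O)(O)O)[C@@H](O)[C@H]1O` gives 0%. Compound 1 `O=C(CI)NCCCNc1ncnc2c1ncn2[C@@H]1O[C@H](COP(=O)(O)OP(=O)(O)OP(=O)(O)O)[C@@H](O)[C@H]1O` carries (((iodomethyl)carbonyl)amino)methyl in place of ((iodomethyl)carbonyl)amino on a saturated chain carbon, two bonds along the chain from a nitrogen on an aromatic ring, and in this assay compound 1 gives 0%, so that no change at the digits printed from compound 3 to compound 1 (within the scatter). Compound 2 `O=C(CI)NCCC(=O)NCCCCCCNc1ncnc2c1ncn2[C@@H]1O[C@H](COP(=O)(O)OP(=O)(O)OP(=O)(O)O)[C@@H](O)[C@H]1O` has a longer linker; how its core differs from that of compound 3 is not broken down here. In this assay compound 2 gives 0%. Compound 4 `O=C(CI)NCCCC(=O)NCCCCCCNc1ncnc2c1ncn2[C@@H]1O[C@H](COP(=O)(O)OP(=O)(O)OP(=O)(O)O)[C@@H](O)[C@H]1O` stands to compound 2 as compound 1 stands to compound 3, with (((iodomethyl)carbonyl)amino)methyl in place of ((iodomethyl)carbonyl)amino on a saturated chain carbon, two bonds along the chain from a carbonyl carbon. The change is of the same kind as that from compound 3 to compound 1, though here the place lies two bonds along the chain from a carbonyl carbon rather than from a nitrogen on an aromatic ring. Because no change at the digits printed from compound 3 to compound 1 (within the scatter), the expected step is no change at the digits printed from compound 2 to compound 4 (within the scatter). Compound 4 is estimated at 0%, between -5% and 8%.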

Compound 4, a percentage reported as inhibition, at one concentration (the size of the read-out at that concentration, not a potency): 0%
Compound 4: the middle estimate sits on the measured number at the digits printed; measured number inside the range.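

On the core of compound 2, setting (((iodomethyl)carbonyl)amino)methyl in place of ((iodomethyl)carbonyl)amino leaves this assay with no change at the digits printed from compound 2 to compound 4 (within the scatter) and so matches the earlier step: the same change on two cores in this assay, no change at the digits printed (within the scatter) from compound 3 to compound 1 and no change at the digits printed (within the scatter) from compound 2 to compound 4, 0 percentage points apart, within the scatter of two such steps
The change therefore carries between these two cores without moving the read-out. Yet compound 4 at 0% reads the same as the other three compounds, so the agreement is between two flat steps and does not show how the change would act on a core with measurable inhibition.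

Left open is whether 2-(((iodomethyl)carbonyl)amino)ethyl or 3-(((iodomethyl)carbonyl)amino)propyl would give any inhibition in this assay on either core. Also open, going by these compounds, is what an amine or a carboxylic acid would do in place of the iodomethyl group.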